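Swapping the benzyl ether for a pyrimidinylmethyl ether

This account rests on a few compounds, and the source may have more. Where it says the series, first, only, none or still open, it means among the compounds named here.

Measured compounds:
compound 1 `Cc1c(C2CC2)nc2ccc(-n3ccc(OCc4ccccc4)cc3=O)cn12` gives 42 nM
compound 2 `Cc1c(C2CC2)nc2ccc(-n3ccc(OCc4ccc(C(C)C)cc4)cc3=O)cn12` gives 410 nM

Within the data shown here, in an assay on CHO cells for displacement of a labelled ligand from melanin-concentrating hormone receptor 1 (Homo sapiens), read by scintillation counting, with a stated time of 1 h (on this read-out higher numbers stand for weaker inhibition and lower numbers for stronger inhibition), compound 2 stands at the higher of the two numbers, with compound 1 the only neighbour. Among the measured compounds shown here, the one step known, a 9.8-fold higher number from compound 1 to compound 2 (0.99 log units; beyond the scatter), is the sole guide. For the measured compounds named here, compound 3 `Cc1c(C2CC2)nc2ccc(-n3ccc(OCc4cncnc4)cc3=O)cn12` differs from compound 2 by pyrimidin-5-yl in place of 4-isopropylphenyl on a saturated chain carbon bound to an oxygen on an aromatic ring, which removes the isopropyl that cost compound 2 its strength and also exchanges the carbon ring for one with two nitrogens; no measured pair speaks to that exchange. A return toward compound 1, partly offset, is expected: a 4.6-fold lower number from compound 2 to compound 3 (0.66 log units; beyond the scatter). Compound 3 is estimated at 90 nM, between 25 nM and 350 nM.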

Compound 3, half-maximal inhibitory concentration: > 1000 nM
Compound 3 gave a limit, no number; the forecaster's own chance of this, stated with the estimate: 3%; middle value at least 11-fold (1.04 log units) away from the limit.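

In this assay, compound 3 gives a limit and not a number: the limit of > 1000 nM in this assay, at which 1 of the 3 values shown sits. Removing the isopropyl did not restore strength here, as the ring itself matters at this position: pyrimidin-5-yl in place of 4-isopropylphenyl gives an at least 2.4-fold higher number from compound 2 to compound 3 (0.38 log units; beyond the scatter), and pyrimidin-5-yl in place of phenyl gives an at least 23-fold higher number from compound 1 to compound 3 (1.37 log units; beyond the scatter). Of the three compounds, compound 3, with two nitrogens in its ring, is the weakest.

Going by these compounds, how far compound 3 lies beyond its limit stays unknown. Also open, on these data alone, is whether a pyridin-3-yl ring, with a single ring nitrogen, would keep the strength of compound 1.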